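A Shorter Chain Bearing Two Chlorines

A few compounds are considered here, and "the series" means these few. Any claim that something is new, unique, unknown or untested is made for them only; others in the source may bear on it.

Compound 1 `O=C(CCCc1ccccc1)Nc1nc2ccccc2c(=O)s1` gives 34.9 nM in an in vitro assay on cells for inhibition of Amine oxidase [flavin-containing] B (Homo sapiens), read by fluorescence and Amplex Red, with stated times of 30 min and 45 min (on this read-out higher numbers stand for weaker inhibition and lower numbers for stronger inhibition), the lowest of the two numbers shown. Compound 2 `O=C(CCCc1ccc(Cl)c(Cl)c1)Nc1nc2ccccc2c(=O)s1` gives 3440 nM in this assay, a step of a 99-fold higher number from compound 1 to compound 2 (1.99 log units; beyond the scatter). For compound 3 `O=C(CCCc1ccccc1)Nc1nc2ccc(Br)cc2c(=O)s1` the read-out in this assay is only a limit, > 10000 nM. That limit, (the limit of > 10000 nM in this assay, at which 1 of the 3 values shown sits), still marks a step of an at least 280-fold higher number from compound 1 to compound 3 (2.45 log units; beyond the scatter). Compound 4 `O=C(CCc1ccc(Cl)c(Cl)c1)Nc1nc2ccccc2c(=O)s1` has not yet been measured; it differs from compound 1 by 3,4-dichlorophenyl in place of benzyl on a saturated chain carbon, two bonds along the chain from a carbonyl carbon, so the chain becomes shorter while gaining the chlorines that compound 2 carries. The step from compound 1 to compound 2 is the closest guide, and a similarly large loss of inhibition is expected. For compound 4 the estimate in this assay is 3000 nM, within 500 nM to 15000 nM, meaning an expected step of an 86-fold higher number from compound 1 to compound 4 (1.93 log units; beyond the scatter).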

Compound 4, half-maximal inhibitory concentration: > 10000 nM
Compound 4: only a limit was reported; the forecaster's own chance of this, stated with the estimate: 20%; at least 3.3-fold (0.52 log units) between middle value and limit.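

Placing 3,4-dichlorophenyl instead of benzyl at this chain position weakens inhibition sharply, with an at least 280-fold higher number from compound 1 to compound 4 (2.45 log units; beyond the scatter). Compound 4 gives only a limit, > 10000 nM, so the shorter chain shows no recovery of the inhibition lost with the chlorines in compound 2. Limits now recur in the set, so the full size of these losses stays unknown: the limit of > 10000 nM in this assay, at which 2 of the 4 values shown sit.

The compounds shown leave open whether the shorter chain alone, bearing a plain phenyl, would keep inhibition. They also leave open how a longer chain or a single chlorine would fare.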